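The source may hold more compounds than are shown below. What is called first, only, known or untested is meant among the compounds shown, and "the series" means these compounds.

Of the compounds shown here, three have been measured in an assay on HEK293 cells for positive allosteric modulation of metabotropic glutamate receptor 2 (Rattus norvegicus), read by thallium flux, with a stated time of 2.5 min; a lower number here means a smaller maximal response, a higher number a larger maximal response. Compound 1, `COC(=O)c1ccc(OCCCCOc2ccc(C(=O)CC3CCCC3)c(O)c2C)cc1`, gives 12.2% in this assay. Compound 2, `COC(=O)c1ccc(OCCCCOc2ccc(C(=O)CC3CCCC3)c(C)c2C)cc1`, gives 14.1% in this assay. Compound 3, `Cc1c(OCCCCOc2ccc(C(=O)O)cc2)ccc(C(=O)CC(C)C)c1C`, gives 19% in this assay; its values against compound 2 and compound 1 lie within the usual scatter of repeated measurements.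

Compound 2 and compound 1 differ in a single place: hydroxy in place of methyl on an aromatic carbon. This change made a step of a number 1.9 percentage points lower from compound 2 to compound 1 (within the scatter), which lies within the scatter. Compound 3 and compound 2 differ in more than one place, and the difference between the two cores is not broken down here; their two values simply stand side by side.

Compound 4, `Cc1c(OCCCCOc2ccc(C(=O)O)cc2)ccc(C(=O)CC(C)C)c1O`, has not yet been measured. It differs from compound 3 in one place: hydroxy in place of methyl on an aromatic carbon. Going by the values given here, this is the same kind of change as the one from compound 2 to compound 1, but not the same: in compound 3 the place is ortho to an isobutylcarbonyl group, whereas in compound 2 it is ortho to a (cyclopentylmethyl)carbonyl group. Because the earlier change made a step of only a number 1.9 percentage points lower from compound 2 to compound 1 (within the scatter), the step expected here is a number 2 percentage points lower from compound 3 to compound 4 (within the scatter), again within the scatter. Compound 4 is therefore estimated at 17%, with an expected range from 9% to 26%.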

Compound 4, largest response reached (reported as percent of maximum), in percent of the reference or control that the assay uses: 88%
Estimate against measurement, compound 4: 71 percentage points below; the whole stated range lies below it.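

On the core of compound 3, putting hydroxy in place of methyl on an aromatic carbon gave a step in this assay of a number 69 percentage points higher from compound 3 to compound 4 (beyond the scatter), so this one change took the maximal response from a low to a high level. Set beside the earlier case, the same change did not carry over from one core to the other in this series: the same change on two cores in this assay, a number 1.9 percentage points lower (within the scatter) from compound 2 to compound 1 and a number 69 percentage points higher (beyond the scatter) from compound 3 to compound 4, 70.9 percentage points apart, beyond the scatter of two such steps

This shows that the outcome of the change depends on the core that carries it, so a step read on one core could not be transferred to the other, but it does not show which feature of the cores decides the outcome, as they differ both in methyl ester against carboxylic acid and in (cyclopentylmethyl)carbonyl against isobutylcarbonyl, and two pairs give no rule for any further core.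

The compounds shown leave open whether the large step goes with the carboxylic acid, with the isobutylcarbonyl group, or only with the two together. They also leave open whether methoxy or an amine in the place of the hydroxy, or a longer chain in the place of the isobutylcarbonyl group, would keep the response seen for compound 4.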